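The compounds below may be only part of what the source reports. "The series", "measured", "known", "first", "only" and "open" are said of these compounds alone.

The measured compounds:

compound 1, `CCn1c(C(=O)NCCC(=O)O)ccc1C(CC)(CC)c1ccc(C#CC(O)(CC)CC)c(C)c1`: 293 nM
compound 2, `CCn1c(C(=O)NCCCO)ccc1C(CC)(CC)c1ccc(C#CC(O)(CC)CC)c(C)c1`: 137 nM
compound 3, `CCn1cc(C(CC)(CC)c2ccc(C#CC(O)(CC)CC)c(C)c2)cc1C(=O)OCCO`: 12.6 nM

Among these three numbers compound 3 stands lowest in an assay on cells for agonist activity at vitamin D3 receptor (Homo sapiens), read by microscopy; on this read-out lower numbers stand for an effect already at smaller amounts and higher numbers for an effect only at larger amounts of compound; its nearest neighbour is compound 2, and compound 1 lies furthest away. Compound 4, `CCn1cc(C(CC)(CC)c2ccc(C#CC(O)(CC)CC)c(C)c2)cc1C(=O)N[C@@H](C)CO`, has not yet been measured. It differs from compound 3 in one place: (1-(hydroxymethyl)ethyl)amino in place of 2-hydroxyethoxy on a carbonyl carbon. For the measured compounds named here, no measured pair shows exactly this exchange of a hydroxy-bearing ester chain for a hydroxy-bearing amide chain. Going by the values given here, the one single-point step available, a 2.1-fold lower number from compound 1 to compound 2 (0.33 log units; beyond the scatter), concerns the end group of a chain on an amide-type nitrogen and was modest. Compound 2 carries an amide with a hydroxy-terminated chain and gives 137 nM, while compound 3 carries an ester with a hydroxy-terminated chain and gives 12.6 nM; these two differ in more than one place, so that gap is not a clean step. On this basis the step to compound 4 is expected to be small to moderate, most likely toward a higher number: a 2.4-fold higher number from compound 3 to compound 4 (0.38 log units; beyond the scatter). Compound 4 is therefore estimated at 30 nM, within 8 nM to 120 nM.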

Compound 4, half-maximal effective concentration: 7.33 nM
Beside the measured number, compound 4's estimate is 4.1-fold (0.61 log units) above it; measured number below the stated range.
By their numbers in this assay, from the lowest: compounds 4 and 3 (each within the scatter of the next); then compound 2; then compound 1.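

In this assay the exchange on a carbonyl carbon whose other neighbour is an aromatic carbon gives a 1.7-fold lower number from compound 3 to compound 4 (0.24 log units; within the scatter) and so leaves no readable change. For the compounds shown here, this is the first single-place comparison of an ester-linked chain and an amide-linked chain, and it shows that (1-(hydroxymethyl)ethyl)amino, with its defined stereocentre, can replace 2-hydroxyethoxy at this place with the number staying within the scatter. The data shown offer no explanation for this result.

What the compounds leave open is how the opposite stereoisomer of the (1-(hydroxymethyl)ethyl)amino chain, or a 2-hydroxyethylamino chain without its methyl group, would read at this position. As far as these compounds go, how a carboxylic acid, a primary amine or a longer hydroxyalkyl chain on this amide would read also remains open.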